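Replacing trifluoromethoxy by fluoro on a shared core

The source may report more compounds than this note shows. Statements on the series, on what has been measured and on what is new or still open speak of the compounds shown alone.

Of the compounds shown here, three built on one core have been measured in a functional assay on Huh-7 cells (Homo sapiens) for inhibition, read by sulforhodamine B assay, with a stated time of 72 h; a higher number here means a weaker inhibitor, a lower number a stronger inhibitor. Compound 1 `COc1ccc2cc(C(C)c3nnc4n3N=C(c3ccc(C)cc3)CS4)ccc2c1` gives 8200 nM. Within the data shown here, compound 3 `COc1ccc2cc(C(C)c3nnc4n3N=C(c3ccc([N+](=O)[O-])cc3)CS4)ccc2c1` gives 14700 nM, and the only single change measured so far, a 1.8-fold higher number from compound 1 to compound 3 (0.25 log units; within the scatter), stays within the scatter. Compound 2 `CC(C)Cc1ccc(C(C)c2nnc3n2N=C(c2ccc(OC(F)(F)F)cc2)CS3)cc1` gives 3600 nM, the lowest number of the three; compound 1 is nearest and compound 3 furthest, and both gaps lie beyond the scatter.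

Compound 4 `CC(C)Cc1ccc(C(C)c2nnc3n2N=C(c2ccc(F)cc2)CS3)cc1` differs from compound 2 in one place: fluoro in place of trifluoromethoxy on an aromatic carbon. Among the measured compounds shown here, no measured step exchanges these two groups, and the one measured step, from compound 1 to compound 3, concerns a different group, so it says little about this change. With nothing pointing strongly either way, the expected step of a 1.4-fold higher number from compound 2 to compound 4 (0.14 log units; within the scatter) from compound 2 to compound 4 is small and may fall within the scatter. Compound 4 is therefore estimated at 5000 nM in this assay, with a range from 2000 nM to 12000 nM.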

Compound 4, half-maximal inhibitory concentration: 7800 nM
Compound 4: the middle estimate sits 1.6-fold (0.19 log units) below what was measured, within the range that was stated.
By their numbers in this assay, from the lowest: compound 2; then compounds 4, 1 and 3 (each within the scatter of the next).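

Exchanging trifluoromethoxy for fluoro in this assay gives a 2.2-fold higher number from compound 2 to compound 4 (0.34 log units; beyond the scatter), a modest step, but one that shows the group on this aromatic carbon can move the number. Among these compounds, the earlier step, a 1.8-fold higher number from compound 1 to compound 3 (0.25 log units; within the scatter), was made at the same place in compounds with a different group elsewhere, and it stayed within the scatter, so this is the first change here to go beyond it. Four heavy atoms fewer enter with fluoro than leave with trifluoromethoxy, but no measurement here explains why the number rises.

The compounds shown leave open which part of trifluoromethoxy matters, something that trifluoromethyl or methoxy on this carbon could help to separate. They also leave open whether the same exchange gives a similar step in the methoxy-bearing compounds 1 and 3.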